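The source may hold more compounds than are shown below. What is called first, only, known or untested is meant among the compounds shown, and "the series" means these compounds.

In an in vitro functional assay on cells for agonist activity at Bombesin receptor subtype-3 (Mus musculus), read by luminescence and calcium flux (on this read-out higher numbers stand for an effect only at larger amounts of compound and lower numbers for an effect already at smaller amounts), compound 2 `CC(C)CCc1cnc(CCc2ccc(-c3ccccc3C(=O)O)cc2)[nH]1` gives 10 nM, the lowest of the two numbers measured; compound 1 `O=C(O)c1ccccc1-c1ccc(CCc2ncc(Cc3ccccc3Cl)[nH]2)cc1` gives 22 nM in this assay. Within the data shown here, the only measured step, a 2.2-fold lower number from compound 1 to compound 2 (0.34 log units; beyond the scatter), shows a change at the same chain carbon. Compound 3 `O=C(O)c1ccccc1-c1ccc(CCc2ncc(CC3CC3)[nH]2)cc1` carries cyclopropyl in place of isobutyl on a saturated chain carbon bound to an aromatic carbon. Among the measured compounds shown here, no measured step covers a smaller group at this position, so the one step on record gives only a loose guide. Compound 3 is therefore expected to show a modest step upward in this assay, a 2.5-fold higher number from compound 2 to compound 3 (0.40 log units; beyond the scatter), with considerable uncertainty. The estimate for compound 3 in this assay is 25 nM, within 8 nM to 80 nM.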

Compound 3, half-maximal effective concentration: 72 nM
For compound 3 the middle estimate is 2.9-fold (0.46 log units) below the measured one; the measured number falls inside the stated range.
By their numbers in this assay, from the lowest: compound 2; then compound 1; then compound 3.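

In this assay this position proves more sensitive than the earlier pair showed: cyclopropyl in place of isobutyl gives a 7.2-fold higher number from compound 2 to compound 3 (0.86 log units; beyond the scatter) and so moves the number further than the first step did. Cyclopropyl in place of 2-chlorophenyl also gives a 3.3-fold higher number from compound 1 to compound 3 (0.51 log units; beyond the scatter) as its result. A ring at this place does not settle the number by itself, since compound 1 carries one too and stays lower than compound 3. Nothing at hand explains the rise. As far as these compounds go, whether a longer chain or a hydroxyl group on this chain carbon would hold or lower the number of compound 2 remains open.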